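This account rests on a few compounds, and the source may have more. Where it says the series, first, only, none or still open, it means among the compounds named here.

Measured so far in an ADME assay on L02 cells (Homo sapiens) for antiproliferative activity, read by MTT assay, with a stated time of 48 h; a higher number here means a weaker inhibitor, a lower number a stronger inhibitor:
Compound 1 `N#CC1=C(N)Oc2c(c3nc4ccccc4nc3c3ccccc23)C12C(=O)N(Cc1cnnn1-c1cccc(Cl)c1)c1ccccc12` gives 35200 nM.
Compound 2 `Cc1ccc(-n2nncc2CN2C(=O)C3(C(C#N)=C(N)Oc4c3c3nc5ccccc5nc3c3ccccc43)c3ccccc32)c(C)c1` gives only a limit, > 50000 nM.
Compound 3 `Cc1ccccc1-n1nncc1CN1C(=O)C2(C(C#N)=C(N)Oc3c(N)cc4nc5ccccc5nc4c32)c2ccccc21` gives only a limit, > 50000 nM.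

Compound 3 thus stands at the limit of this assay and offers no number; see (the limit of > 50000 nM in this assay, at which 2 of the 3 values shown sit). Compound 4 `Cc1ccc(-n2nncc2CN2C(=O)C3(C(C#N)=C(N)Oc4c(N)cc5nc6ccccc6nc5c43)c3ccccc32)cc1C` differs from it by 3,4-dimethylphenyl in place of 2-methylphenyl on an aromatic nitrogen. Among the compounds with values here, the one measured step, an at least 1.4-fold higher number from compound 1 to compound 2 (0.15 log units; that floor lies within the scatter), also changes the group on this aromatic nitrogen and runs toward weaker inhibition, but it ends at the limit, so its size is only a floor. On that basis compound 4 is expected to stay at or beyond the limit, with an estimated step that the limit leaves unreadable from compound 3 to compound 4 that is not expected to stand apart from the scatter. The estimate for compound 4 is 70000 nM, within 35000 nM to 150000 nM.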

Compound 4, half-maximal inhibitory concentration: > 50000 nM
Compound 4 was reported as a limit; the forecaster's own chance of this, stated with the estimate: 75%; the middle value is on the limit's open side.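

In this assay compound 3 and compound 4 both stand at a limit and not at a number, and no step can be read between them. The compounds shown leave open how 3,4-dimethylphenyl and 2-methylphenyl compare on the aromatic nitrogen.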